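Chalcones on Liver Cancer Cells: Hydroxy Replaces Imidazole

This account rests on a few compounds, and the source may have more. Where it says the series, first, only, none or still open, it means among the compounds named here.

Measured so far, in a functional assay on HepG2 cells (Homo sapiens) for antiproliferative activity, read by MTT assay, with a stated time of 24 h; on this read-out higher numbers stand for weaker inhibition and lower numbers for stronger inhibition:
Compound 1 `COc1ccc(C(=O)/C=C/c2cc(OC)c(OC)c(OC)c2)c2c1C=CC(C)(C)O2` gives > 10000 nM, which is a limit of the assay.
Compound 2 `COc1ccc(C(=O)/C=C/c2ccc(-n3ccnc3)cc2)c2c1C=CC(C)(C)O2` gives > 10000 nM, again a limit.
Compound 3 `COc1ccc(C(=O)/C=C/c2ccc(OC)c(OC)c2OC)c2c1C=CC(C)(C)O2` gives > 10000 nM, also a limit.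

All three compounds share the same core and differ only in the ring attached to the carbon–carbon double bond. Among the measured compounds shown here, none of them has yielded a number: each sits at the limit of > 10000 nM in this assay, at which 3 of the 3 values shown sit, so no compound can be ranked against another, and compound 2 stands simply among the others at that limit.

Compound 4 `COc1ccc(C(=O)/C=C/c2ccc(O)cc2)c2c1C=CC(C)(C)O2` has not yet been tested. The change from compound 2 is hydroxy in place of 1H-imidazol-1-yl on an aromatic carbon. For the measured compounds named here, no step between measured compounds is available to show how such a change shifts the read-out, and the three measured compounds give no spread to lean on.

With nothing pointing the other way, the step from compound 2 to compound 4 in this assay is expected to be a step that the limit leaves unreadable from compound 2 to compound 4, which is none beyond the scatter; most likely compound 4 will also only reach the limit. Compound 4 is therefore estimated at 15000 nM, within a range from 5000 nM to 50000 nM.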

Compound 4, half-maximal inhibitory concentration: > 10000 nM
Compound 4 was reported as a limit; the forecaster's own chance of this, stated with the estimate: 75%; the middle value is on the limit's open side.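

Compound 2 and compound 4 both end at a limit rather than a number, so the swap of 1H-imidazol-1-yl for hydroxy gives no step that can be read in this assay: the limit of > 10000 nM in this assay, at which 4 of the 4 values shown sit.

The compounds shown leave open whether any ring on this shared core can give a real number here, and how these four rank against one another.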